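The compounds below may be only part of what the source reports. "The series", "measured", "known", "first", "only" and "open" are said of these compounds alone.

Compound 1 `CCCCOC(=O)CC1NS(=O)(=O)c2c(C)cccc21`: "not determined" (no result reported) in an assay on HEK-Blue hNOD1 cells for antagonist activity at Nucleotide-binding oligomerization domain-containing protein 1 (Homo sapiens), read by reporter gene assay, with stated times of 3 h and 20 h; on this read-out lower numbers stand for stronger inhibition and higher numbers for weaker inhibition.
Compound 2 `CCCCOC(=O)CC1c2cccc(C)c2S(=O)(=O)N1C(=O)c1ccc(C(F)(F)F)cc1`: 1310 nM in this assay.
Compound 3 `COC(=O)CC1c2cccc(C)c2S(=O)(=O)N1C(=O)c1ccc(C(F)(F)F)cc1`: 2980 nM in this assay.

Among the measured compounds shown here, compound 3 holds the highest of the two numbers; its nearest neighbour is compound 2, and a 2.3-fold higher number from compound 2 to compound 3 (0.36 log units; beyond the scatter) is the only change measured. Compound 4 `Cc1cccc2c1S(=O)(=O)N(C(=O)c1ccc(C(F)(F)F)cc1)C2CC(=O)OC(C)(C)C` is the next step: tert-butyl in place of methyl on an oxygen next to a carbonyl group. For the measured compounds named here, the one measured step bears on this change, as it too altered the group on the oxygen next to a carbonyl group, and there the shorter chain gave the higher number. Compound 4 is therefore expected to move back to a lower number, a 2.0-fold lower number from compound 3 to compound 4 (0.30 log units; within the scatter), because a 2.3-fold higher number from compound 2 to compound 3 (0.36 log units; beyond the scatter) ran the other way when carbons were removed, though a branched group has not been tested. Compound 4 is estimated at 1500 nM, within 700 nM to 3500 nM.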

Compound 4, half-maximal inhibitory concentration: 8120 nM
Estimate against measurement, compound 4: 5.4-fold (0.73 log units) below; the whole stated range lies below it.
By their numbers in this assay, from the lowest: compound 2; then compound 3; then compound 4.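

In this assay, the group on the oxygen next to a carbonyl group is not ordered by chain length alone. Tert-butyl in place of methyl raises the number (a 2.7-fold higher number from compound 3 to compound 4 (0.44 log units; beyond the scatter)), and tert-butyl in place of butyl raises it as well (a 6.2-fold higher number from compound 2 to compound 4 (0.79 log units; beyond the scatter)), so the branched compound 4 goes against the lower number seen with the longer straight chain in compound 2. Nothing available explains this order.

Still open, on these data alone, is how an isopropyl group, a benzyl group or the free carboxylic acid would read at this place.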